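Chloro for Amino on a Fused Core: Cytotoxicity Outlook

The compounds below may be only part of what the source reports. "The series", "measured", "known", "first", "only" and "open" are said of these compounds alone.

Compound 1, `ClCc1ccc(Cn2cnc3c(Cl)ncnc32)cc1`: > 100000 nM
Compound 2, `Nc1nc(Cl)c2ncn(Cc3ccc(CCl)cc3)c2n1`: 57500 nM

Of the compounds shown here, two have been tested in a functional assay on OVCAR-4 cells (Homo sapiens) for cytotoxicity, read by sulforhodamine B assay, with a stated time of 48 h; on this read-out higher numbers stand for lower toxicity in this test and lower numbers for higher toxicity in this test. For compound 1 the result is a limit of the assay, > 100000 nM, as recorded in the limit of > 100000 nM in this assay, at which 1 of the 2 values shown sits. In this assay, within the data shown here, compound 2 gives 57500 nM, the only number in the set. Among the measured compounds shown here, the single measured step, an at least 1.7-fold lower number from compound 1 to compound 2 (0.24 log units; that floor lies within the scatter), is amino in place of hydrogen on an aromatic carbon, and its floor lies within the scatter.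

Compound 3, `ClCc1ccc(Cn2cnc3c(Cl)nc(Cl)nc32)cc1`, differs from compound 2 by chloro in place of amino on an aromatic carbon. The measured step runs from hydrogen to amino, whereas this one runs from amino to chloro, so it bears on the present change only loosely: the amino group coincided with a number that was, at most, modestly lower. For the measured compounds named here, no step shows what chloro does at this position. Compound 3 is therefore expected at 70000 nM, within 25000 nM to 200000 nM. The expected step of a 1.2-fold higher number from compound 2 to compound 3 (0.09 log units; within the scatter) is no larger than the scatter, with a fair chance that this assay reports only a limit.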

Compound 3, concentration lethal to 50% of the cells: 61700 nM
For compound 3 the middle estimate is 1.1-fold (0.05 log units) above the measured one; the range from low to high includes it.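

In this assay, among these compounds, the first direct comparison at this position, between two ring nitrogen atoms, shows that chloro in place of amino gives values within the scatter of each other: a 1.1-fold higher number from compound 2 to compound 3 (0.03 log units; within the scatter). Among the compounds shown here, it also gives the first reading of chloro against hydrogen at this position, an at least 1.6-fold lower number from compound 1 to compound 3 (0.20 log units; that floor lies within the scatter), which is a floor within the scatter, so it does not establish a real difference between those two groups. The true size of any step from compound 1 cannot be read, because the value of compound 1 is a limit of the assay: the limit of > 100000 nM in this assay, at which 1 of the 3 values shown sits.

The compounds shown leave open whether a different group at this position, such as a methoxy group, a methyl group or a longer amine chain, would shift the number beyond the scatter. They also leave open what happens when the chloro group meta to this position, which all three compounds carry, gives way to an amine or a hydroxyl group.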